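The source may report more compounds than this note shows. Statements on the series, on what has been measured and on what is new or still open speak of the compounds shown alone.

Series notes on the shared core of compound 1 `CCOC(=O)c1cnc(-c2ccccc2)nc1NN1C(=O)C=C(C)C1=O`. In a functional assay on Jurkat cells for inhibition of nuclear factor NF-kappa-B complex (Homo sapiens) (a lower number here means a stronger inhibitor, a higher number a weaker inhibitor), compound 1 gives 100 nM. Compound 2 `CCOC(=O)c1cnc(-c2ccc(F)cc2)nc1NN1C(=O)C=C(C)C1=O` gives 700 nM in this assay, and compound 3 `CCOC(=O)c1cnc(CC2=CCCCC2)nc1NN1C(=O)C=C(C)C1=O` gives 2000 nM. Compound 3 stands highest of the three numbers: the nearest is compound 2, at a 2.9-fold higher number from compound 2 to compound 3 (0.46 log units; beyond the scatter), and the furthest is compound 1, at a 20-fold higher number from compound 1 to compound 3 (1.30 log units; beyond the scatter). Both gaps lie beyond the scatter, so compound 3 is the weakest inhibitor of the three in this assay.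

Compound 4 `CCOC(=O)c1cnc(Cc2ccccc2)nc1NN1C(=O)C=C(C)C1=O` is not yet measured. It differs from compound 3 in one place: phenyl in place of cyclohex-1-en-1-yl on a saturated chain carbon bound to an aromatic carbon. For the measured compounds named here, no measured step exchanges these two groups on the chain carbon, so the bearing steps are indirect. The step of a 20-fold higher number from compound 1 to compound 3 (1.30 log units; beyond the scatter) moves from phenyl on the aromatic carbon to the (cyclohex-1-en-1-yl)methyl chain, a large rise in this assay; the step of a 2.9-fold higher number from compound 2 to compound 3 (0.46 log units; beyond the scatter) moves from 4-fluorophenyl to the same chain, a modest rise. Compound 4 keeps the one-carbon chain but carries phenyl at its end, and the step of a 7.0-fold higher number from compound 1 to compound 2 (0.85 log units; beyond the scatter) shows that changes on the phenyl ring itself stay within a modest span. A downward step in this assay, beyond the scatter but short of a full return to the level of compound 1, is therefore expected, of about a 4.0-fold lower number from compound 3 to compound 4 (0.60 log units; beyond the scatter). Compound 4 is estimated at 500 nM, with a range of 150 nM to 2000 nM.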

Compound 4, half-maximal inhibitory concentration: 7000 nM
Compound 4: the middle estimate sits 14-fold (1.15 log units) below what was measured; the whole stated range lies below it.
By their numbers in this assay, from the lowest: compound 1; then compound 2; then compound 3; then compound 4.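

With the chain carbon held in place, phenyl in place of cyclohex-1-en-1-yl in this assay gives a 3.5-fold higher number from compound 3 to compound 4 (0.54 log units; beyond the scatter) and does not recover the level of the compounds with an aryl group directly on the aromatic carbon, so the aromatic end ring alone does not account for the strength of compound 1. Benzyl in place of phenyl gives a 70-fold higher number from compound 1 to compound 4 (1.85 log units; beyond the scatter) as the widest gap in the set, and benzyl in place of 4-fluorophenyl gives a 10-fold higher number from compound 2 to compound 4 (1.00 log units; beyond the scatter) as well, which makes compound 4 the weakest inhibitor of the four and points to the chain carbon as the costly feature among these compounds. No measurement shown accounts for these steps.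

The compounds shown leave open how cyclohex-1-en-1-yl behaves directly on the aromatic carbon, which would separate the effect of the end ring from that of the chain carbon. They also leave open whether a longer chain, or a fluoro, amine or carboxylic acid group on the benzyl ring, moves the number further in either direction.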